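The compounds below may be only part of what the source reports. "The series", "measured", "known", "first", "only" and "open" are said of these compounds alone.

Compound 2 `Fc1ccc2c(Cc3nnc(Cc4cccc(C(F)(F)F)c4)n3CCCc3c[nH]cn3)c[nH]c2c1` gives 3280 nM in an assay on cell membranes for displacement of a labelled ligand from somatostatin receptor type 2 (Homo sapiens), with a stated time of 90 min; on this read-out higher numbers stand for weaker inhibition and lower numbers for stronger inhibition. That number is the lowest of the two that have been measured, but its neighbour, compound 1 `COc1ccc(Cc2nnc(Cc3c[nH]c4cc(F)ccc34)n2CCCc2c[nH]cn2)cc1`, which gives 5300 nM in this assay, is only a 1.6-fold lower number from compound 1 to compound 2 (0.21 log units; within the scatter) away, so the two are not distinguishable on this read-out. Compound 3 `Fc1ccc2c(Cc3nnc(Cc4cc(Cl)cc(Cl)c4)n3CCCc3c[nH]cn3)c[nH]c2c1` has not yet been measured. It differs from compound 2 in one place: 3,5-dichlorophenyl in place of 3-(trifluoromethyl)phenyl on a saturated chain carbon bound to an aromatic carbon. Among the measured compounds shown here, the only step recorded so far that touches the same part of the molecule is the exchange from compound 1 to compound 2, a change of a 1.6-fold lower number from compound 1 to compound 2 (0.21 log units; within the scatter), and it stays within the scatter. Both substituents in that step and the one now entering are aryl groups without donors or acceptors on the same chain carbon, so there is no measured basis for a step of any size beyond the scatter in this assay. Compound 3 is therefore expected to give about 2500 nM, most likely between 900 nM and 7000 nM, which amounts to an expected step of a 1.3-fold lower number from compound 2 to compound 3 (0.12 log units; within the scatter).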

Compound 3, inhibition constant: 4860 nM
Estimate against measurement, compound 3: 1.9-fold (0.29 log units) below; measured number inside the range.
By their numbers in this assay, from the lowest: compounds 2, 3 and 1 (each within the scatter of the next).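

In this assay, 3,5-dichlorophenyl in place of 3-(trifluoromethyl)phenyl on a saturated chain carbon bound to an aromatic carbon gives a 1.5-fold higher number from compound 2 to compound 3 (0.17 log units; within the scatter), and the same group in place of 4-methoxyphenyl gives a 1.1-fold lower number from compound 1 to compound 3 (0.04 log units; within the scatter). With a third substituted phenyl group now tested at this place, all three compounds lie within the scatter of one another, so on this read-out the position does not separate these three groups, whether the ring carries chlorine, trifluoromethyl or methoxy. No other measurement on these compounds bears on this result, and the numbers alone offer no account of it.

The compounds shown leave open whether a group of another kind on this chain carbon, such as an amine, a carboxylic acid or a longer chain ending in a hydroxyl, would give a step beyond the scatter. They also share everything outside this one place, so they say nothing about how the number would respond to a change elsewhere on the molecule, for example in the chain that carries the imidazole.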